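Phenyl in place of hydrogen on the amide chain of compound 2

The source may hold more compounds than are shown below. What is called first, only, known or untested is meant among the compounds shown, and "the series" means these compounds.

Three compounds share one core. Compound 1 is `Nc1ccc(Cl)cc1C1=NN(C(=O)c2ccccc2)CC1`, compound 2 is `CCC(=O)N1CCC(c2cc(OC)ccc2N)=N1` and compound 3 is `CCCC(=O)N1CCC(c2cc(OC)ccc2N)=N1`. In an assay on isolated protein for inhibition of Nitric oxide synthase, inducible (Homo sapiens), with a stated time of 30 min, tested at 1 mM (a lower number here means less inhibition, a higher number more inhibition at the concentration tested (going by the name of the read-out)), compound 2 gives 20.4%. Compound 1 gives 17% and compound 3 gives 13.1%, both within the usual scatter of the number for compound 2. For the measured compounds named here, the only single-place step measured, a number 7.3 percentage points lower from compound 2 to compound 3 (within the scatter), stays within that scatter.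

Compound 4 is `COc1ccc(N)c(C2=NN(C(=O)CCc3ccccc3)CC2)c1`. It differs from compound 2 by phenyl in place of hydrogen on a saturated chain carbon, two bonds along the chain from a carbonyl carbon. The step from compound 2 to compound 3 sits at the same place and is the only one that bears on this change; it was a number 7.3 percentage points lower from compound 2 to compound 3 (within the scatter). Compound 4 is therefore expected to show no step beyond the scatter, a number 2.4 percentage points lower from compound 2 to compound 4 (within the scatter). The estimate for compound 4 is 18%, within 7% to 32%.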

Compound 4, a percentage reported as inhibition, at one concentration (the size of the read-out at that concentration, not a potency): 21.2%
Estimate against measurement, compound 4: 3.2 percentage points below, and the stated range covers the measured number.
By their numbers in this assay, from the lowest: compounds 3, 1, 2 and 4 (each within the scatter of the next).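

In this assay, phenyl in place of hydrogen on the saturated chain carbon, two bonds along the chain from a carbonyl carbon, gives a number 0.8 percentage points higher from compound 2 to compound 4 (within the scatter) and so extends the earlier methyl result to an aromatic ring. Phenyl in place of methyl at the same place gives a number 8.1 percentage points higher from compound 3 to compound 4 (within the scatter) as the reading. Hydrogen, methyl and phenyl at this place therefore show no step beyond the scatter.

Going by these compounds, whether an amine, a carboxylic acid or a longer chain at this place would give a step beyond the scatter stays open. No measurement on hand accounts for these numbers.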